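Pyrazoline-thiazolone series: methoxy to dimethylamino on the pendant phenyl

This account rests on a few compounds, and the source may have more. Where it says the series, first, only, none or still open, it means among the compounds named here.

Measured so far in a functional assay on cells (Cancer cell lines, Homo sapiens) for cytotoxicity, read by sulforhodamine B assay, with a stated time of 48 h; a higher number here means a weaker inhibitor of growth, a lower number a stronger inhibitor of growth:
compound 1 `COc1ccc(C2CC(c3ccccc3)=NN2C2=NC(=O)/C(=C3\C(=O)Nc4ccccc43)S2)cc1`: 3350 nM
compound 2 `COc1ccc(C2CC(c3ccccc3)=NN2C2=NC(=O)/C(=C3\C(=O)Nc4ccc(Br)cc43)S2)cc1`: 660 nM
compound 3 `COc1ccc(C2=NN(C3=NC(=O)/C(=C4\C(=O)Nc5ccc(Br)cc54)S3)C(c3ccc(OC)cc3)C2)cc1`: 710 nM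

Compound 2 gives the lowest number of the three, though its gap to compound 3 is within the scatter; only compound 1 sits clearly apart, a 5.1-fold lower number from compound 1 to compound 2 (0.71 log units; beyond the scatter). The second step, a 1.1-fold higher number from compound 2 to compound 3 (0.03 log units; within the scatter), shows that adding a methoxy to the other phenyl leaves this assay unchanged.

Compound 4 `CN(C)c1ccc(C2CC(c3ccccc3)=NN2C2=NC(=O)/C(=C3\C(=O)Nc4ccc(Br)cc43)S2)cc1` differs from compound 2 by dimethylamino in place of methoxy on an aromatic carbon. Going by the values given here, neither measured step touches this group, so no direct precedent exists; the bromo step is not comparable, and the methoxy step was flat. The expectation is therefore a step within the scatter, a 1.1-fold higher number from compound 2 to compound 4 (0.03 log units; within the scatter). Compound 4 is estimated at 700 nM, with a range from 300 nM to 1600 nM.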

Compound 4, concentration for total growth inhibition: 720 nM
Compound 4: the middle estimate sits 1.0-fold (0.01 log units) below what was measured; measured number inside the range.
By their numbers in this assay, from the lowest: compounds 2, 3 and 4 (each within the scatter of the next); then compound 1.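

At the pendant phenyl, which neither earlier step touched, the swap to dimethylamino gives a 1.1-fold higher number from compound 2 to compound 4 (0.04 log units; within the scatter) in this assay and leaves the two groups indistinguishable. Within this pair, therefore, the position accepts dimethylamino in place of methoxy with no separation in growth inhibition. No independent evidence bears on this result.

On these data alone, whether a hydroxyl, a primary amine or a carboxylic acid at this position would stay in the same range remains open. So does whether dimethylamino would behave the same way on the core lacking bromo.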